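The source may report more compounds than this note shows. Statements on the series, on what has been measured and on what is new or still open speak of the compounds shown alone.

Measured in a functional assay on PANC-1 cells (Homo sapiens) for inhibition, read by MTT assay, with a stated time of 24 h, tested at 10 uM; on this read-out lower numbers stand for less inhibition and higher numbers for more inhibition at the one concentration tested (going by the name of the read-out):
compound 1, `CC(C)=CCC1Cc2c(OC(=O)Nc3cccc(F)c3)cc(=O)n(CCCO)c2CC1(C)C`: 0%
compound 2, `CC(C)=CCC1Cc2c(OC(=O)Nc3ccccc3F)cc(=O)n(CCCO)c2CC1(C)C`: 0%
compound 3, `CC(C)=CCC/C(C)=C/CC1Cc2c(OC(=O)Nc3cccc(F)c3)cc(=O)n(CCCO)c2CC1(C)C`: 0%

Compound 2 differs from compound 1 by 2-fluorophenyl in place of 3-fluorophenyl on an amide-type nitrogen, and in this assay this gave no change at the digits printed from compound 1 to compound 2 (within the scatter). The core of compound 3 differs from the core of compound 1 by 3-methylbut-2-en-1-yl in place of hydrogen on a saturated chain carbon bound to a double-bonded chain carbon, which gave no change at the digits printed from compound 1 to compound 3 (within the scatter). Compound 4, `CC(C)=CCC/C(C)=C/CC1Cc2c(OC(=O)Nc3ccccc3F)cc(=O)n(CCCO)c2CC1(C)C`, has not yet been measured; it differs from compound 3 by 2-fluorophenyl in place of 3-fluorophenyl on an amide-type nitrogen, the same change as that from compound 1 to compound 2, made at the same place. For compound 4 in this assay a step of no change at the digits printed from compound 3 to compound 4 (within the scatter) is expected, because the earlier instance gave no change at the digits printed from compound 1 to compound 2 (within the scatter) and because compound 3 itself gives 0%. Compound 4 is therefore estimated at 0%, in a range from 0% to 10%.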

Compound 4, a percentage reported as inhibition, at one concentration (the size of the read-out at that concentration, not a potency): 0%
The estimate for compound 4 equals the measured number at the digits printed; measured number inside the range.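

In this assay, 2-fluorophenyl in place of 3-fluorophenyl gave no change at the digits printed from compound 3 to compound 4 (within the scatter), matching the earlier instance: the same change on two cores in this assay, no change at the digits printed (within the scatter) from compound 1 to compound 2 and no change at the digits printed (within the scatter) from compound 3 to compound 4, 0 percentage points apart, within the scatter of two such steps
3-methylbut-2-en-1-yl in place of hydrogen gave no change at the digits printed from compound 2 to compound 4 (within the scatter), again matching its earlier instance: the same change on two cores in this assay, no change at the digits printed (within the scatter) from compound 1 to compound 3 and no change at the digits printed (within the scatter) from compound 2 to compound 4, 0 percentage points apart, within the scatter of two such steps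
Among the compounds shown here, compound 4 gives 0%, the reading shared by all four compounds, so the agreement shows only that neither change, alone or together, brought out any inhibition in this assay at the one concentration tested; it does not show how either change would carry over between cores that show measurable inhibition.

The compounds shown leave open which structural change, if any, would give a reading above this level. One such question is whether an amine or a carboxylic acid in place of the fluorine would do so.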